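Aryl Exchange on the Piperazine Nitrogen, Oxime Series

The compounds below may be only part of what the source reports. "The series", "measured", "known", "first", "only" and "open" are said of these compounds alone.

Measured so far:
compound 1 `N#Cc1cccnc1N1CCN(CC/C(=N\O)c2ccccc2)CC1` gives 18 nM
compound 2 `CCO/N=C(\CCN1CCN(c2ccccc2OC)CC1)c1ccccc1` gives 338 nM

Two compounds have been run in a functional assay on HEK293 cells with D(4) dopamine receptor (Homo sapiens) as the target, read by FLIPR; on this read-out lower numbers stand for an effect already at smaller amounts and higher numbers for an effect only at larger amounts of compound. Compound 1 gives 18 nM and compound 2 gives 338 nM; compound 2 therefore stands at the higher of the two numbers, and the gap to compound 1 lies well beyond the scatter. The two differ in more than one place, so no single-change step can be read from them.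

Compound 3 `CCO/N=C(\CCN1CCN(c2ncccc2C#N)CC1)c1ccccc1` is next, not yet measured in this assay. It arises from compound 2 by 3-cyanopyridin-2-yl in place of 2-methoxyphenyl on an amine nitrogen in a ring. For the measured compounds named here, the group that enters is the one carried by compound 1, the compound with the lower number. On this basis a move toward lower numbers is expected, beyond the scatter, though the other difference between compound 1 and compound 3 leaves the size uncertain. The step expected a 7.5-fold lower number from compound 2 to compound 3 (0.88 log units; beyond the scatter) is thus a clear drop. For compound 3 the expected value in this assay is 45 nM, estimated within 12 nM to 160 nM.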

Compound 3, half-maximal effective concentration: 139 nM
Compound 3: middle estimate off by 3.1-fold (0.49 log units), on the low side, and the stated range covers the measured number.
By their numbers in this assay, from the lowest: compound 1; then compound 3; then compound 2.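

In this assay, 3-cyanopyridin-2-yl in place of 2-methoxyphenyl on the amine nitrogen in the ring, with ethyl kept on the oxygen, gives a 2.4-fold lower number from compound 2 to compound 3 (0.39 log units; beyond the scatter) and so isolates a modest effect of this exchange, beyond the scatter. Ethyl in place of hydrogen on the oxygen, with 3-cyanopyridin-2-yl kept on the ring nitrogen, gives a 7.7-fold higher number from compound 1 to compound 3 (0.89 log units; beyond the scatter) and shows that this second place also moves the number beyond the scatter, with ethyl on the side of the higher number. Nothing at hand gives a reason for either step, so both stand here as observations only.

The compounds shown leave open how the same aryl exchange runs with hydrogen on the oxygen, and therefore whether the two steps simply add or depend on each other. Also open, from the compounds shown here alone, is how a methyl or a longer chain on that oxygen would read, and whether the nitrile matters on its own, a question that a plain pyridin-2-yl or a 3-carboxypyridin-2-yl on the ring nitrogen would address.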